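Aryl amide variation on a shared core: compound 4

The source may hold more compounds than are shown below. What is called first, only, known or untested is meant among the compounds shown, and "the series" means these compounds.

Measured so far in an ADME assay on HaCaT cells (Homo sapiens) for inhibition; on this read-out higher numbers stand for weaker inhibition and lower numbers for stronger inhibition:
Compound 1 `COc1cc(-c2cc(C(=O)O)c3ccccc3n2)ccc1OCC(=O)Nc1ccccc1C` gives 230000 nM.
Compound 2 `COc1cc(-c2cc(C(=O)O)c3ccccc3n2)ccc1OCC(=O)Nc1ccc(C)cc1` gives only a limit, > 300000 nM.
Compound 3 `COc1cc(-c2cc(C(=O)O)c3ccccc3n2)ccc1OCC(=O)Nc1ccccc1F` gives 161000 nM.

Within the data shown here, compound 2 stands at the limit of this assay, (the limit of > 300000 nM in this assay, at which 1 of the 3 values shown sits); it is the one compound of the three for which no number is known. Compound 4 `COc1cc(-c2cc(C(=O)O)c3ccccc3n2)ccc1OCC(=O)Nc1ccccc1Cl` differs from compound 2 in one place: 2-chlorophenyl in place of 4-methylphenyl on an amide-type nitrogen.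

Two measured steps connect the 4-methylphenyl compound with compounds carrying a substituent at the 2-position of the phenyl: an at least 1.3-fold higher number from compound 1 to compound 2 (0.11 log units; that floor lies within the scatter) and an at least 1.8-fold lower number from compound 2 to compound 3 (0.27 log units; that floor lies within the scatter). Both rest on the limit, so only floors are known, and both floors lie within the scatter. The third step, a 1.4-fold lower number from compound 1 to compound 3 (0.15 log units; within the scatter), exchanges the 2-substituent itself and stays within the scatter. Compound 4 carries a 2-chlorophenyl, so its step from compound 2 is expected to resemble the two steps toward compounds 1 and 3: a lower number, possibly no larger than the scatter, and the estimate is an at least 1.5-fold lower number from compound 2 to compound 4 (0.19 log units; that floor lies within the scatter).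

For compound 4 in this assay the expected value is 190000 nM, in the range 100000 nM to 400000 nM.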

Compound 4, half-maximal inhibitory concentration: 210000 nM
Estimate against measurement, compound 4: 1.1-fold (0.04 log units) below, and the stated range covers the measured number.
By their numbers in this assay, from the lowest: compounds 3, 4 and 1 (each within the scatter of the next). At a limit, above all of these: compound 2.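

In this assay, the 2-chlorophenyl amide cannot be separated from the other two compounds with a single substituent at the 2-position of the phenyl: a 1.1-fold lower number from compound 1 to compound 4 (0.04 log units; within the scatter), and a 1.3-fold higher number from compound 3 to compound 4 (0.12 log units; within the scatter). Chloro, methyl and fluoro on this aromatic carbon therefore read as equivalent within the scatter, and the set of 2-substituted phenyl amides now spans three substituents without any step that rises above it. The comparison with the 4-methylphenyl amide gains only one more floor, an at least 1.4-fold lower number from compound 2 to compound 4 (0.15 log units; that floor lies within the scatter), so it still shows no step beyond the scatter, and compound 2 remains a limit and not a number: the limit of > 300000 nM in this assay, at which 1 of the 4 values shown sits.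

Going by these compounds, whether the 4-methylphenyl compound truly differs from the 2-substituted compounds stays open, and a 4-chlorophenyl or 4-fluorophenyl amide would separate the effect of the substituent's place from that of its identity only if it gave a number rather than a limit. Also open, on these data alone, is whether a markedly different group on this phenyl, such as a 2-aminophenyl, a 2-methoxyphenyl or a 2-trifluoromethylphenyl, or an unsubstituted phenyl, would move the value beyond the scatter.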